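This account rests on a few compounds, and the source may have more. Where it says the series, first, only, none or still open, it means among the compounds named here.

Measured compounds:
- compound 1 `CS(=O)(=O)c1ccc(Cc2n[nH]c(=S)n2/N=C/c2cccnc2)cc1`: 16.9%
- compound 2 `CS(=O)(=O)c1ccc(Cc2n[nH]c(=S)n2/N=C/c2ccccc2Cl)cc1`: 34.7%

In a functional assay on HeLa cells (Homo sapiens) for cytotoxicity, read by MTT assay, with a stated time of 48 h, tested at 12.5 uM (on this read-out higher numbers stand for a stronger effect at the one concentration tested and lower numbers for a weaker effect), compound 1 gives 16.9%, while compound 2 gives 34.7%. Within the data shown here, compound 2 thus stands highest of the two numbers, and the single measured step, a number 17.8 percentage points higher from compound 1 to compound 2 (beyond the scatter), set it apart from compound 1 beyond the scatter.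

Compound 3 `CS(=O)(=O)c1ccc(Cc2n[nH]c(=S)n2/N=C/c2c(F)cccc2Cl)cc1` differs from compound 2 by one change: fluoro in place of hydrogen on an aromatic carbon. Among the measured compounds shown here, no measured step speaks to this change; the one step known swaps a whole ring for another, whereas here a single fluorine enters a ring that is otherwise kept. There is therefore nothing to suggest a shift beyond the scatter in either direction, and the expectation is that compound 3 stays close to compound 2.

The estimate for compound 3 in this assay is 38%, expected to lie between 20% and 58%, an expected step of a number 3.3 percentage points higher from compound 2 to compound 3 (within the scatter).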

Compound 3, a percentage reported as activity, at one concentration (the size of the read-out at that concentration, not a potency): 49.8%
Compound 3: middle estimate off by 11.8 percentage points, on the low side; the measured number falls inside the stated range.
By their numbers in this assay, from the lowest: compound 1; then compound 2; then compound 3.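

Among these compounds, measured in this assay with the ring otherwise kept, fluoro in place of hydrogen gives a number 15.1 percentage points higher from compound 2 to compound 3 (beyond the scatter) and so shows that one added atom on this aromatic carbon can matter, where the earlier compounds showed only the exchange of a whole ring. Set against the pyridin-3-yl ring, the 2-chloro-6-fluorophenyl ring gives a number 32.9 percentage points higher from compound 1 to compound 3 (beyond the scatter) and thus widens the range seen so far in this series. Nothing at hand explains why this fluoro raises the number.

Going by these compounds, whether the rise is particular to fluoro remains open, since an amine, a methoxy group or a second chloro group on the same carbon could read differently. Also open, on these data alone, is whether fluoro would have a similar effect on a ring without the chloro group.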